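Methyl on the distal ring across two cores

The compounds below may be only part of what the source reports. "The series", "measured", "known", "first", "only" and "open" are said of these compounds alone.

Compound 1 `C/C(=C\c1cc(-c2cccnc2)co1)C(N)=O` and compound 2 `C/C(=C\c1cc(-c2ccc(C)nc2)co1)C(N)=O` share one core; compound 3 `C/C(=C\c1cc(-c2ccccc2)cs1)C(N)=O` and the unmeasured compound 4 `C/C(=C\c1cc(-c2ccc(C)cc2)cs1)C(N)=O` share another, and the difference between the two cores is not broken down here. In a functional assay on HeLa cells (Homo sapiens) for cytotoxicity, read by CCK-8 assay, with a stated time of 24 h (on this read-out lower numbers stand for stronger inhibition and higher numbers for weaker inhibition), compound 1 gives only a limit, > 50000 nM. Compound 2 likewise gives only a limit, > 50000 nM. Compound 3 gives 12700 nM in this assay. The change from compound 1 to compound 2, (methyl in place of hydrogen on an aromatic carbon), yields a step that the two limits leave unreadable from compound 1 to compound 2, because both sit at the limit of > 50000 nM in this assay, at which 2 of the 3 values shown sit. Compound 4 arises from compound 3 by methyl in place of hydrogen on an aromatic carbon, the same kind of change but not the same: the place differs, a ring of carbon only rather than a ring with 1 nitrogen, next to the ring nitrogen. The step is expected to be a 1.4-fold lower number from compound 3 to compound 4 (0.15 log units; within the scatter), resting only on compound 3 at 12700 nM and a precedent that is unreadable. Compound 4 is expected to give 9000 nM, between 3000 nM and 30000 nM.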

Compound 4, half-maximal inhibitory concentration: > 50000 nM
Compound 4 gave a limit, no number (the forecaster's own chance of this, stated with the estimate: 15%); at least 5.5-fold (0.74 log units) between middle value and limit.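

In this assay methyl in place of hydrogen on an aromatic carbon of the core of compound 3 gives an at least 3.9-fold higher number from compound 3 to compound 4 (0.59 log units; beyond the scatter) and so goes with weaker inhibition on that core. Compound 4 stands at a limit (> 50000 nM), not a number. The data do not show that the change behaves alike on both cores, because the step from compound 1 to compound 2 cannot be read: the limit of > 50000 nM in this assay, at which 3 of the 4 values shown sit.

Still open, going by these compounds, is how the number of compound 3 responds when a different group, such as an amine, a carboxylic acid or a longer chain, takes the place of that hydrogen. Also open, on these data alone, is whether any such group on the core of compound 1 gives a readable number.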